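From cyclopentyl to 4-hydroxycyclohexyl on a shared core

The source may report more compounds than this note shows. Statements on the series, on what has been measured and on what is new or still open speak of the compounds shown alone.

Among the measured compounds shown here, only two compounds have been measured so far, and compound 2 `CN1CCN(c2ccc(Nc3ncc4nc(Sc5ccccc5)n(C5CCCC5)c4n3)cc2)CC1` holds the lower number. In a functional assay on A549 cells (Homo sapiens) for antiproliferative activity, read by MTT assay, with a stated time of 72 h (on this read-out higher numbers stand for weaker inhibition and lower numbers for stronger inhibition), compound 2 gives 237 nM, whereas compound 1 `CN1CCN(c2ccc(Nc3ncc4nc(Sc5ccccc5)n(C5CCOCC5)c4n3)cc2)CC1` gives 2950 nM. The two share a core and differ only in the group on an aromatic nitrogen. Putting cyclopentyl in place of oxan-4-yl there gave a 12-fold lower number from compound 1 to compound 2 (1.10 log units; beyond the scatter), a large step beyond the scatter.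

Compound 3 `CN1CCN(c2ccc(Nc3ncc4nc(Sc5ccccc5)n([C@H]5CC[C@H](O)CC5)c4n3)cc2)CC1` changes the same place, with 4-hydroxycyclohexyl in place of cyclopentyl on an aromatic nitrogen. For the measured compounds named here, that single step is the only measured evidence at this position, so it is a thin guide. Like the oxan-4-yl group of compound 1, the entering group is a six-membered ring containing oxygen, although here the oxygen sits outside the ring. The measured 12-fold lower number from compound 1 to compound 2 (1.10 log units; beyond the scatter) therefore suggests that compound 3 will lose part of the activity gained, without necessarily returning all the way. The expected move is a 3.4-fold higher number from compound 2 to compound 3 (0.53 log units; beyond the scatter), towards weaker inhibition. The estimate for compound 3 is 800 nM, with an expected range from 170 nM to 3500 nM.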

Compound 3, half-maximal inhibitory concentration: 426 nM
For compound 3 the middle estimate is 1.9-fold (0.27 log units) above the measured one; low and high end bracket the measured number.
By their numbers in this assay, from the lowest: compounds 2 and 3 (each within the scatter of the next); then compound 1.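

In this assay, putting 4-hydroxycyclohexyl in place of cyclopentyl on the aromatic nitrogen gives a 1.8-fold higher number from compound 2 to compound 3 (0.25 log units; within the scatter), so these two groups cannot be told apart here, even though the entering group is a larger six-membered ring with a hydrogen-bond donor and acceptor that cyclopentyl lacks. Oxan-4-yl is a different matter: putting 4-hydroxycyclohexyl in its place gives a 6.9-fold lower number from compound 1 to compound 3 (0.84 log units; beyond the scatter), a modest step. Taken together, these steps show that an oxygen in the group does not by itself go with the weak number, since oxan-4-yl, with its oxygen in the ring, and 4-hydroxycyclohexyl, with its oxygen outside the ring, read differently at this position.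

Nothing at hand explains the gap between these two oxygen-bearing groups. Also open, on these data alone, is whether an amine on the ring, as in 4-aminocyclohexyl, or a carboxylic acid in that spot would read like the hydroxyl group, and whether the other spatial arrangement of the hydroxyl group would give a similar number.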